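The source may report more compounds than this note shows. Statements on the series, on what has been measured and on what is new or still open speak of the compounds shown alone.

Working notes on the shared core of compound 1 `CCOC(=O)/C(=N\O)c1ccc(Sc2cc(F)cc(C3CCOCC3)c2)cc1`, compound 2 `C/C(=N\OC(=O)C(C)(C)C)c1ccc(Sc2cc(F)cc(C3CCOCC3)c2)cc1` and compound 3 `CC(C)/C(=N\O)c1ccc(Sc2cc(F)cc(C3CCOCC3)c2)cc1`. In a functional assay (blood) for inhibition, with Homo sapiens as the target (on this read-out higher numbers stand for weaker inhibition and lower numbers for stronger inhibition), compound 1 gives 170 nM, compound 2 gives 40 nM and compound 3 gives 300 nM. Among these three numbers compound 3 stands highest: the nearest is given by a 1.8-fold higher number from compound 1 to compound 3 (0.25 log units; within the scatter), which stays within the scatter, and the furthest by a 7.5-fold higher number from compound 2 to compound 3 (0.88 log units; beyond the scatter), which lies beyond it. Compound 4 `CC(=O)/C(=N\O)c1ccc(Sc2cc(F)cc(C3CCOCC3)c2)cc1` is not yet measured in this assay. The change: acetyl in place of isopropyl on a carbon with a double bond to nitrogen.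

The step that bears most directly on this change is a 1.8-fold higher number from compound 1 to compound 3 (0.25 log units; within the scatter), in which a group carrying a carbonyl on the same carbon was swapped for isopropyl with little effect. The step of a 4.3-fold lower number from compound 1 to compound 2 (0.63 log units; beyond the scatter) also alters the oxime region, but in a different manner and only as a loose guide. For compound 4 in this assay a small step toward a lower number is therefore expected, a 1.5-fold lower number from compound 3 to compound 4 (0.18 log units; within the scatter), probably not beyond the scatter. Compound 4 is estimated at 200 nM, with a range from 80 nM to 500 nM.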

Compound 4, half-maximal inhibitory concentration: 850 nM
Beside the measured number, compound 4's estimate is 4.3-fold (0.63 log units) below it; the measured number lies above the stated range.
By their numbers in this assay, from the lowest: compound 2; then compounds 1 and 3 (each within the scatter of the next); then compound 4.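

In this assay, this position separates acetyl from isopropyl: a 2.8-fold higher number from compound 3 to compound 4 (0.45 log units; beyond the scatter). A carbonyl on this carbon does not by itself set the number, since replacing ethoxy with methyl on that carbonyl carbon gives a 5.0-fold higher number from compound 1 to compound 4 (0.70 log units; beyond the scatter), and compound 4 also lies well away from the best compound shown, with a 21-fold higher number from compound 2 to compound 4 (1.33 log units; beyond the scatter). No measured evidence is available to explain these differences.

From the compounds shown here alone, whether a carboxylic acid, a primary amide or a longer ketone chain on this carbon would track compound 4 or compound 1 remains open. The step to compound 2 involves a larger group change, so the share of that gap belonging to each part of the change also stays unresolved.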